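The source may hold more compounds than are shown below. What is called first, only, known or untested is meant among the compounds shown, and "the series" means these compounds.

Measured in a functional assay on DU-145 cells (Homo sapiens) for inhibition, read by trypan blue exclusion, with a stated time of 96 h; on this read-out higher numbers stand for weaker inhibition of growth and lower numbers for stronger inhibition of growth:
- compound 1 `O=C(/C(=C\c1ccc(Cl)cc1)S(=O)(=O)c1ccc(Br)cc1)c1ccc(Br)cc1`: 50000 nM
- compound 2 `COc1ccc(/C=C(\C(=O)c2ccc(Br)cc2)S(=O)(=O)c2ccc(Br)cc2)c(F)c1`: 10000 nM
- compound 3 `O=C(/C(=C\c1ccc(Br)cc1)S(=O)(=O)c1ccc(Br)cc1)c1ccc(Br)cc1`: 10000 nM

Compound 3 is level with compound 2 at the digits shown, and the two share the lowest of the three numbers. Compound 4 `O=C(/C(=C\c1ccc(F)cc1)S(=O)(=O)c1ccc(Br)cc1)c1ccc(Br)cc1` carries fluoro in place of bromo on an aromatic carbon, para to a large group (fluoro in place of bromo on an aromatic carbon). The closest measured step is the exchange of one halogen for another at this place, a 5.0-fold lower number from compound 1 to compound 3 (0.70 log units; beyond the scatter), a modest step. The change of the whole aryl group, no change at the digits printed from compound 2 to compound 3 (within the scatter), shows that a different substitution can leave the number unchanged. Fluoro at this place has not been measured, so the size of the step is uncertain. A modest step toward a higher number is expected in this assay, similar to or smaller than the reverse of the step to the bromo compound. The estimated step is a 3.0-fold higher number from compound 3 to compound 4 (0.48 log units; beyond the scatter). Compound 4 is expected at about 30000 nM, with an estimated range of 10000 nM to 80000 nM.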

Compound 4, concentration for 50% growth inhibition: 4000 nM
Compound 4: middle estimate off by 7.5-fold (0.88 log units), on the high side; measured number outside the range, below it.
By their numbers in this assay, from the lowest: compound 4; then compounds 2 and 3 (each within the scatter of the next); then compound 1.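

In this assay, the change from 4-bromophenyl to 4-fluorophenyl gives a 2.5-fold lower number from compound 3 to compound 4 (0.40 log units; beyond the scatter), and compound 4 now holds the lowest number of the four, with its steps to all the others beyond the scatter. Going by these compounds alone, the halogen alone spans a 13-fold lower number from compound 1 to compound 4 (1.10 log units; beyond the scatter), the largest step so far, and the order fluoro, bromo, chloro from lowest to highest number does not follow the order of these halogens in the periodic table. The plain 4-fluorophenyl group also gives a lower number than the 2-fluoro-4-methoxyphenyl group, with a 2.5-fold lower number from compound 2 to compound 4 (0.40 log units; beyond the scatter).

No data at hand explain this ranking of the halogens. Open questions are how a nitrile or an amine would read at this place, and whether fluoro in place of the two remaining bromo groups of the shared core would lower the number further.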